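This account rests on a few compounds, and the source may have more. Where it says the series, first, only, none or still open, it means among the compounds named here.

Three compounds have so far been measured in a functional assay on U-87MG ATCC cells for antiproliferative activity against U-87 MG (Homo sapiens), read by MTT assay, with a stated time of 48 h, tested at 5 uM; on this read-out lower numbers stand for a stronger effect and higher numbers for a weaker effect at the one concentration tested:

compound 1, `COc1ccc(-c2nc(SCC(=O)c3sc(-c4ccccc4)nc3C)[nH]c(=O)c2C#N)cc1`, gives 97.3%;
compound 3, `COc1ccc(-c2nc(SCC(=O)c3sc(-c4ccc(Cl)cc4)nc3C)[nH]c(=O)c2C#N)cc1`, gives 92.1%;
compound 2, `Cc1nc(-c2ccccc2)sc1C(=O)CSc1nc(N)c(C#N)c(-c2ccc(Cl)cc2)n1`, gives 62.9%.

Compound 3 and compound 1 share one core and differ in a single place: hydrogen in place of chloro on an aromatic carbon. The resulting step, a number 5.2 percentage points higher from compound 3 to compound 1 (within the scatter), is small. Compound 2 stands lowest of the three numbers in this assay; its nearest neighbour is compound 3 and its furthest is compound 1, both of them beyond the scatter. The difference between the core of compound 2 and the core of compound 3 is not broken down here.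

Compound 4, `Cc1nc(-c2ccccc2)sc1C(=O)CSc1nc(N)c(C#N)c(-c2ccccc2)n1`, has not yet been measured. Going by the values given here, it differs from compound 2 by hydrogen in place of chloro on an aromatic carbon, and this is the same change as the one from compound 3 to compound 1, made at the same kind of place. Because a number 5.2 percentage points higher from compound 3 to compound 1 (within the scatter) stayed within the scatter, the step from compound 2 to compound 4 is expected to be of the same small size, a number 5.1 percentage points higher from compound 2 to compound 4 (within the scatter). Compound 4 is therefore estimated to give 68% in this assay, expected to fall between 55% and 82%.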

Compound 4, a percentage reported as activity, at one concentration (the size of the read-out at that concentration, not a potency): 103%
Estimate against measurement, compound 4: 35 percentage points below, outside the stated range (above it).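

In this assay, the change from 4-chlorophenyl to phenyl gives a number 40.1 percentage points higher from compound 2 to compound 4 (beyond the scatter), so on this core removing the chloro is far from the small step seen earlier. The size of the step therefore did not carry from one core to the other: the same change on two cores in this assay, a number 5.2 percentage points higher (within the scatter) from compound 3 to compound 1 and a number 40.1 percentage points higher (beyond the scatter) from compound 2 to compound 4, 34.9 percentage points apart, beyond the scatter of two such steps This shows only that, for these two pairs, the step cannot be assumed to be the same on both cores; it does not show which of the differences between the cores lies behind the gap, nor does it yield a rule for the series as a whole.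

What the compounds shown leave open is how the step would look on a third core, since only two pairs are available for comparison. They also leave open what other groups in place of the chloro would do on the core of compound 2, such as fluoro, bromo, a methyl group or an amine, since only chloro and hydrogen appear at this place.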